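The compounds below may be only part of what the source reports. "The series", "measured", "known", "first", "only" and "open" are said of these compounds alone.

Of the compounds shown here, three have been measured so far: compound 1 `CCCSc1nc(N/N=C(\C)c2ccccc2O)c2nnn(Cc3ccccc3Cl)c2n1`, compound 2 `CCCSc1nc(N/N=C/c2ccc(N(C)C)cc2)c2nnn(Cc3ccccc3)c2n1` and compound 3 `C#CCSc1nc(N/N=C/c2ccc(N(C)C)cc2)c2nnn(Cc3ccccc3)c2n1`. In a functional assay on ECa-109 cells (Homo sapiens) for antiproliferative activity, read by MTT assay, with a stated time of 72 h (a lower number here means a stronger inhibitor, a higher number a weaker inhibitor), compound 1 gives only a limit, > 64000 nM, so where it stands among the numbers is open. Compound 2 gives 20000 nM in this assay. Compound 3 gives 31300 nM. Among the compounds with values here, the one step between measured compounds, a 1.6-fold higher number from compound 2 to compound 3 (0.19 log units; within the scatter), concerns ethynyl in place of ethyl on a saturated chain carbon bound to a sulfur, a different change from the one followed here.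

Compound 4 `CCCSc1nc(N/N=C(\C)c2ccccc2O)c2nnn(Cc3ccc(O)cc3)c2n1` differs from compound 1 by 4-hydroxyphenyl in place of 2-chlorophenyl on a saturated chain carbon bound to an aromatic nitrogen. Within the data shown here, no measured step touches this change, and the starting point is itself a limit (the limit of > 64000 nM in this assay, at which 1 of the 3 values shown sits), so no direction can be read from the data. Compound 4 is therefore expected to remain weak, the expected step being an at least 1.0-fold lower number from compound 1 to compound 4 (0.02 log units; that floor lies within the scatter). The estimate for compound 4 is 60000 nM, between 20000 nM and 200000 nM.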

Compound 4, half-maximal inhibitory concentration: 15900 nM
Estimate against measurement, compound 4: 3.8-fold (0.58 log units) above, outside the stated range (below it).
By their numbers in this assay, from the lowest: compounds 4, 2 and 3 (each within the scatter of the next). At a limit, above all of these: compound 1.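

In this assay, the group on the saturated chain carbon bound to an aromatic nitrogen proves able to shift the result: 4-hydroxyphenyl in place of 2-chlorophenyl, with the rest of the molecule unchanged, gives an at least 4.0-fold lower number from compound 1 to compound 4 (0.60 log units; beyond the scatter). As far as these compounds go, this step has only a floor, and its full size is unknown, for compound 1 carries a limit, not a number: the limit of > 64000 nM in this assay, at which 1 of the 4 values shown sits.

From the compounds shown here alone, the chlorine leaving and the hydroxy group entering happen together here, so their separate shares stay open. Going by these compounds, how a 4-methoxyphenyl or 4-aminophenyl group would read at this place also remains open.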